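Quinoline thiosemicarbazones on HL-60: methoxyphenyl positional change

The source may hold more compounds than are shown below. What is called first, only, known or untested is meant among the compounds shown, and "the series" means these compounds.

Measured so far:
- compound 1, `COc1ccc(C)cc1NC(=S)N/N=C/c1ccc2ccccc2n1`, > 100000 nM
- compound 2, `COc1cccc(NC(=S)N/N=C/c2ccc3ccccc3n2)c1`, 71200 nM
- compound 3, `CN(C)C(=S)N/N=C/c1cc2cccnc2s1`, > 100000 nM

Among the compounds with values here, in a functional assay on HL-60 cells (Homo sapiens) for antiproliferative activity, read by sulforhodamine B assay, with a stated time of 72 h (a higher number here means a weaker inhibitor, a lower number a stronger inhibitor), compound 2 gives 71200 nM, and this is the only numerical value in the set. Compound 1 reaches only the limit > 100000 nM, which is a limit and not a number. Compound 3 likewise sits at the limit > 100000 nM. Within the data shown here, the evidence on the set is therefore thin: the limit of > 100000 nM in this assay, at which 2 of the 3 values shown sit, describes two of the three entries, so compound 2 stands as the one compound with a measurable, weak effect.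

Compound 4, `COc1ccc(NC(=S)N/N=C/c2ccc3ccccc3n2)cc1`, is not yet measured. It differs from compound 2 as follows: 4-methoxyphenyl in place of 3-methoxyphenyl on an amide-type nitrogen. Among the measured compounds shown here, no step between measured compounds is available to calibrate such a change. The expectation is a step of a 1.3-fold higher number from compound 2 to compound 4 (0.10 log units; within the scatter) of no clear direction beyond the scatter, with a real chance that compound 4 only reaches the assay limit as compounds 1 and 3 do. Compound 4 is estimated at 90000 nM, within 30000 nM to 250000 nM.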

Compound 4, half-maximal inhibitory concentration: 43800 nM
Estimate against measurement, compound 4: 2.1-fold (0.31 log units) above; low and high end bracket the measured number.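

In this assay, 4-methoxyphenyl in place of 3-methoxyphenyl on the amide-type nitrogen gives a 1.6-fold lower number from compound 2 to compound 4 (0.21 log units; within the scatter). Within the data shown here, this is the first step that can be read, and it shows that, at this place, the two methoxyphenyl isomers cannot be told apart in this assay, so the series now holds two numbers that agree within the scatter. Compound 1 and compound 3 still give only a limit and no number: the limit of > 100000 nM in this assay, at which 2 of the 4 values shown sit.

Among these compounds, the only change tested in a one-place step is this shift of the methoxy group, so it remains open whether any other group at this place can move the number beyond the scatter. Open cases include an unsubstituted phenyl, an amine, a carboxylic acid, or a longer chain such as butoxy in place of the methoxy.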